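A few compounds are considered here, and "the series" means these few. Any claim that something is new, unique, unknown or untested is made for them only; others in the source may bear on it.

Measured so far: compound 1 `COc1ccc(C(/C=C/c2ccc(F)cc2)=N/O)cc1` with 11000 nM; compound 2 `O/N=C(\C=C\c1ccc(Cl)cc1)c1ccc(Cl)cc1` with 9150 nM.

In a functional assay (Mus musculus, strain Balb/c) for inhibition, read by ELISA, with a stated time of 72 h (a higher number here means a weaker inhibitor, a lower number a stronger inhibitor), compound 2 gives 9150 nM, the lowest of the two numbers shown, while compound 1 gives 11000 nM, which sits within the scatter of it. Compound 3 `O/N=C(\C=C\c1ccc(F)cc1)c1ccc(Cl)cc1` has not yet been measured in this assay. It differs from compound 2 by fluoro in place of chloro on an aromatic carbon. Going by the values given here, no step between measured compounds shows what this change does, and the two measured numbers lie close together, so no step beyond the scatter is expected. For compound 3 the estimated value in this assay is 10000 nM, with a range from 4000 nM to 25000 nM. The step this estimate means, a 1.1-fold higher number from compound 2 to compound 3 (0.04 log units; within the scatter), is expected to remain within the scatter.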

Compound 3, half-maximal inhibitory concentration: 10600 nM
Beside the measured number, compound 3's estimate is 1.1-fold (0.03 log units) below it; the range from low to high includes it.
By their numbers in this assay, from the lowest: compounds 2, 3 and 1 (each within the scatter of the next).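

Going by these compounds alone, compound 3 gives the first readings of single changes on an aromatic carbon in this assay: fluoro in place of chloro gives a 1.2-fold higher number from compound 2 to compound 3 (0.06 log units; within the scatter), and chloro in place of methoxy, at a different place, gives a 1.0-fold lower number from compound 1 to compound 3 (0.02 log units; within the scatter). Neither step goes beyond the scatter, so fluoro and chloro read alike at one place, as do chloro and methoxy at the other. Nothing available explains these readings. On these data alone, it remains open whether an amine or a carboxylic acid at either place would move the number beyond the scatter. These steps also cannot show which place matters more.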